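The source may report more compounds than this note shows. Statements on the series, on what has been measured and on what is new or still open speak of the compounds shown alone.

For the measured compounds named here, compound 3 `COc1nn2cc(-c3cc4c(OC)cccc4o3)nc2s1` gives 350 nM in an assay for antagonist activity at proteinase-activated receptor 4 (Homo sapiens), with stated times of 5 min, 50 s and 15 min, in the presence of a further agent that is not named here (on this read-out higher numbers stand for weaker inhibition and lower numbers for stronger inhibition), and stands second highest of the three numbers measured so far; compound 2 `COc1nn2cc(-c3cc4ccccc4o3)nc2s1` gives 240 nM, within the scatter of compound 3, whereas compound 1 `COc1nn2cc(-c3cc4c(OC)ccc(OC)c4o3)nc2s1` gives 2100 nM, and a 6.0-fold lower number from compound 1 to compound 3 (0.78 log units; beyond the scatter). Compound 4 `COc1cc(OC)c2cc(-c3cn4nc(OC)sc4n3)oc2c1` differs from compound 3 by methoxy in place of hydrogen on an aromatic carbon. Going by the values given here, two steps bear on adding a methoxy to the shared core. The step of a 1.5-fold higher number from compound 2 to compound 3 (0.16 log units; within the scatter) shows that the first methoxy made no difference beyond the scatter in this assay, while the reverse of a 6.0-fold lower number from compound 1 to compound 3 (0.78 log units; beyond the scatter) shows that a second methoxy, on another aromatic carbon, raised the number modestly. Compound 4 carries its second methoxy at a place not yet tested, so a rise in this assay no larger than that is expected, a 2.6-fold higher number from compound 3 to compound 4 (0.41 log units; beyond the scatter). Compound 4 is estimated at 900 nM, range 300 nM to 2700 nM.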

Compound 4, half-maximal inhibitory concentration: 74 nM
Compound 4: the middle estimate sits 12-fold (1.09 log units) above what was measured; the measured number lies below the stated range.
By their numbers in this assay, from the lowest: compound 4; then compounds 2 and 3 (each within the scatter of the next); then compound 1.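

In this assay, a second methoxy on the shared core does not always raise the number: at this place, meta to a fused ring, para to a fused ring and meta to a methoxy group, the result is a 4.7-fold lower number from compound 3 to compound 4 (0.67 log units; beyond the scatter), the opposite direction to the second methoxy of compound 1. The same change therefore moves the number either way, depending on its place on the ring. Nothing measured here accounts for this difference. On these data alone, it remains open whether a fluorine, an amine or a longer alkoxy chain at this place would give a lower number, and whether this methoxy has the same effect without the first one.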